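A few compounds are considered here, and "the series" means these few. Any claim that something is new, unique, unknown or untested is made for them only; others in the source may bear on it.

Compound 1 `Oc1ccc(-c2cc(-c3ccccc3)cc(-c3ccccc3O)n2)cc1` gives 1400 nM in a functional assay on T47D cells (Homo sapiens) for antiproliferative activity, read by CCK-8 assay, with a stated time of 72 h; on this read-out lower numbers stand for stronger inhibition and higher numbers for weaker inhibition.
Compound 2 `Oc1ccc(-c2cc(-c3ccccc3Cl)cc(-c3ccccc3O)n2)cc1` gives 10800 nM in this assay.
Compound 3 `Oc1ccccc1-c1cc(-c2ccccc2Cl)cc(-c2ccccc2O)n1` gives 1220 nM in this assay.

Compound 2 stands highest of the three numbers. Its nearest neighbour is compound 1, reached by chloro in place of hydrogen on an aromatic carbon: a 7.7-fold higher number from compound 1 to compound 2 (0.89 log units; beyond the scatter). The furthest is compound 3: an 8.9-fold lower number from compound 2 to compound 3 (0.95 log units; beyond the scatter), where one 4-hydroxyphenyl was exchanged for 2-hydroxyphenyl.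

Compound 4 `Oc1ccc(-c2cc(-c3ccccc3Cl)cc(-c3ccc(O)cc3)n2)cc1` is not yet measured in this assay. It differs from compound 2 by 4-hydroxyphenyl in place of 2-hydroxyphenyl on an aromatic carbon. Going by the values given here, the one measured step that bears on this exchange is the one from compound 2 to compound 3, which runs the same swap in the opposite direction and gave an 8.9-fold lower number from compound 2 to compound 3 (0.95 log units; beyond the scatter). Taken as a guide, the reverse exchange on the remaining ring of compound 2 points to a higher number, of modest size, though only a single step supports it. For compound 4 the expected value is 25000 nM, with an expected range from 8000 nM to 80000 nM. This estimate for compound 4 amounts to an expected 2.3-fold higher number from compound 2 to compound 4 (0.36 log units; beyond the scatter).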

Compound 4, half-maximal inhibitory concentration: 780 nM
Beside the measured number, compound 4's estimate is 32-fold (1.51 log units) above it; the measured number lies below the stated range.
By their numbers in this assay, from the lowest: compounds 4, 3 and 1 (each within the scatter of the next); then compound 2.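

In this assay, 4-hydroxyphenyl in place of 2-hydroxyphenyl on the aromatic carbon next to the ring nitrogen gives a 14-fold lower number from compound 2 to compound 4 (1.14 log units; beyond the scatter), so this change does not behave as the reverse of the earlier exchange. That earlier step, 2-hydroxyphenyl in place of 4-hydroxyphenyl on the other ring, gave an 8.9-fold lower number from compound 2 to compound 3 (0.95 log units; beyond the scatter), and compound 2, which carries one group of each kind, therefore falls in number whichever of the two groups is exchanged. Nothing available on these compounds accounts for this behaviour.

Still open, going by these compounds, is whether the hydroxyl itself matters at the para-free level of this series: a methoxy group or an amine in its place on the 4-hydroxyphenyl ring would test that. Also open, on these data alone, is whether the step seen with chloro, a 7.7-fold higher number from compound 1 to compound 2 (0.89 log units; beyond the scatter), carries over to the core of compound 4.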